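Caco-2 permeability of the sulfonamide series: compound 4

The source may hold more compounds than are shown below. What is called first, only, known or untested is meant among the compounds shown, and "the series" means these compounds.

Measured so far:
compound 1 `Cn1cncc1CN1CC(N(CC2CCN(C(=O)CNC(=O)OC(C)(C)C)CC2)S(=O)(=O)c2ccccn2)Cc2cc(C#N)ccc21`: 0.5 10^-6 cm/s
compound 2 `Cn1cncc1CN1CC(N(CC2CCN(S(C)(=O)=O)CC2)S(=O)(=O)c2ccccn2)Cc2cc(C#N)ccc21`: 0.1 10^-6 cm/s
compound 3 `C=C(C)C(=O)N1CCC(CN(C2Cc3cc(C#N)ccc3N(Cc3cncn3C)C2)S(=O)(=O)c2ccccn2)CC1`: 0.5 10^-6 cm/s

In an ADME assay on Caco-2 cells (Homo sapiens) for permeability, in the apical to basolateral direction (on this read-out higher numbers stand for higher permeability and lower numbers for lower permeability), compound 3 sits level with compound 1, the two together giving the highest numbers of the three; compound 2 is the furthest from compound 3, with a 5.0-fold higher number from compound 2 to compound 3 (0.70 log units; beyond the scatter) read in the other direction.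

Compound 4 `Cn1cncc1CN1CC(N(CC2CCN(C(=O)OC(C)(C)C)CC2)S(=O)(=O)c2ccccn2)Cc2cc(C#N)ccc21` is the next member, differing from compound 3 in one place: tert-butoxy in place of 1-methylethenyl on a carbonyl carbon.

Going by the values given here, two measured steps bear on this. First, no change at the digits printed from compound 1 to compound 3 (within the scatter) shows that exchanging a group that carries a tert-butoxycarbonyl for the 1-methylethenyl leaves the number unchanged, so carbonyl-attached groups of this kind are not separating the compounds so far. Second, a 5.0-fold lower number from compound 1 to compound 2 (0.70 log units; beyond the scatter) and a 5.0-fold higher number from compound 2 to compound 3 (0.70 log units; beyond the scatter) show that the only step that moved this assay was the one to a methylsulfonyl on the ring nitrogen, which is not involved here. The change in compound 4 keeps a carbonyl on that nitrogen, so a step of a 1.6-fold higher number from compound 3 to compound 4 (0.20 log units; within the scatter) is expected, that is, nothing clearly beyond the scatter, with a possible drift upward. Compound 4 is therefore estimated at 0.8 10^-6 cm/s, between 0.3 10^-6 cm/s and 2 10^-6 cm/s.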

Compound 4, apparent permeability: 15.5 10^-6 cm/s
For compound 4 the middle estimate is 19-fold (1.29 log units) below the measured one; the measured number lies above the stated range.
By their numbers in this assay, from the lowest: compound 2; then compounds 1 and 3 (each within the scatter of the next); then compound 4.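

In this assay, going by these compounds alone, the group on the carbonyl carbon is not silent, as the earlier compounds had suggested: tert-butoxy in place of 1-methylethenyl gives a 31-fold higher number from compound 3 to compound 4 (1.49 log units; beyond the scatter) and tert-butoxy in place of ((tert-butoxycarbonyl)amino)methyl gives a 31-fold higher number from compound 1 to compound 4 (1.49 log units; beyond the scatter) on the same carbon. Within the data shown here, with a 160-fold higher number from compound 2 to compound 4 (2.19 log units; beyond the scatter) for tert-butoxycarbonyl in place of methylsulfonyl, this position spans a far wider range than the earlier steps showed, and compound 1, which carries a tert-butoxycarbonyl further out, stays within the scatter of compound 3, so that group alone does not go with the high number. No measurement shown accounts for the size of this step.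

On these data alone, it remains open whether the step follows the oxygen or the carbons of tert-butoxy. A methoxy, a dimethylamino or a cyclobutyl group on that carbonyl carbon would separate the two.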